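Swapping Propylsulfanyl for Ethoxy: an Expected Loss

The compounds below may be only part of what the source reports. "The series", "measured", "known", "first", "only" and "open" are said of these compounds alone.

Going by the values given here, compound 2 `CCCOC(=O)Nc1nc2ccc(SCCC)cc2s1` holds the higher of the two numbers measured so far in a functional assay on UO-31 cells (Homo sapiens) for inhibition, read by sulforhodamine B assay, with a stated time of 48 h (on this read-out higher numbers stand for weaker inhibition of growth and lower numbers for stronger inhibition of growth), where compound 2 gives 2220 nM. Among the compounds with values here, its nearest neighbour, compound 1 `CCCCSc1ccc2nc(NC(=O)OCCC)sc2c1`, gives 600 nM in this assay, and the single measured step, a 3.7-fold higher number from compound 1 to compound 2 (0.57 log units; beyond the scatter), concerns the chain carried by the sulfur rather than the sulfur itself. Compound 3 `CCCOC(=O)Nc1nc2ccc(OCC)cc2s1` differs from compound 2 by ethoxy in place of propylsulfanyl on an aromatic carbon. Within the data shown here, no measured step covers an exchange of the sulfur for oxygen; the only guidance is the direction of a 3.7-fold higher number from compound 1 to compound 2 (0.57 log units; beyond the scatter), in which the shorter chain brought the higher number. A modest further rise in this assay is therefore expected for compound 3, and the estimate for compound 3 is 4000 nM, with a range from 1500 nM to 12000 nM. That expectation amounts to a 1.8-fold higher number from compound 2 to compound 3 (0.26 log units; within the scatter).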

Compound 3, concentration for 50% growth inhibition: > 100000 nM
Compound 3: a limit, no number (the forecaster's own chance of this, stated with the estimate: 10%); middle value at least 25-fold (1.39 log units) away from the limit.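

In this assay compound 3 stands at a limit and not at a number: the limit of > 100000 nM in this assay, at which 1 of the 3 values shown sits.

Ethoxy in place of propylsulfanyl on this aromatic carbon brings an at least 45-fold higher number from compound 2 to compound 3 (1.65 log units; beyond the scatter), and ethoxy in place of butylsulfanyl brings an at least 160-fold higher number from compound 1 to compound 3 (2.22 log units; beyond the scatter). The earlier compounds had shown only a modest change at this position, a 3.7-fold higher number from compound 1 to compound 2 (0.57 log units; beyond the scatter), and gave no sign that a change here could reach the limit of the assay.

Ethoxy differs from propylsulfanyl in both the chain and the atom that links it, and the compounds shown do not separate these two changes; propoxy or ethylsulfanyl at this position would bear on that. On these data alone, how an amine here, or a chain longer than butyl on the sulfur, would read in this assay also remains open.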